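A few compounds are considered here, and "the series" means these few. Any claim that something is new, unique, unknown or untested is made for them only; others in the source may bear on it.

Three compounds share one core, each carrying a different nitrogen-bearing group on it. Compound 1 `CN(C)c1ccc(O)c2ccccc12`, compound 2 `CCC(=O)Nc1ccc(O)c2ccccc12` and compound 3 `Cc1ccc(S(=O)(=O)Nc2ccc(O)c3ccccc23)cc1` differ only in that group, and compound 3 is the one whose nitrogen is joined to a sulfonyl sulfur bearing a 4-methylphenyl. In an assay on isolated protein for inhibition of histone acetyltransferase KAT2B (Homo sapiens), read by fluorescence, with a stated time of 5 min, in the presence of a further agent that is not named here (a lower number here means a stronger inhibitor, a higher number a weaker inhibitor), compound 1 gives 4200 nM, and compound 3 gives 12000 nM. For compound 2 the entry reads "not determined" (no result reported), so no number exists for it. Among the two numbers that exist, compound 3 therefore holds the higher one, meaning the weaker inhibition, and its gap to compound 1 lies beyond the usual scatter of repeated measurements.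

Compound 4 `CS(=O)(=O)Nc1ccc(O)c2ccccc12` keeps the sulfonamide of compound 3 but alters what sits on its sulfonyl sulfur: methyl in place of 4-methylphenyl on a sulfonyl sulfur. Within the data shown here, no pair of measured compounds shows the effect of such a change, so nothing in these data says whether losing the six-membered aromatic ring helps or hurts. Among the measured compounds shown here, the only guide is that compound 3, the sole sulfonamide measured, already sits at the weak end. The expected step from compound 3 to compound 4 is a 1.7-fold higher number from compound 3 to compound 4 (0.22 log units; within the scatter), toward slightly weaker inhibition, with a step within the scatter in either direction nearly as likely. Compound 4 is expected to give about 20000 nM in this assay, most likely between 6000 nM and 70000 nM.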

Compound 4, half-maximal inhibitory concentration: 3800 nM
Beside the measured number, compound 4's estimate is 5.3-fold (0.72 log units) above it; measured number below the stated range.
By their numbers in this assay, from the lowest: compounds 4 and 1 (each within the scatter of the next); then compound 3.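

In this assay, the group on the sulfonyl sulfur proves to matter: methyl in place of 4-methylphenyl gives a 3.2-fold lower number from compound 3 to compound 4 (0.50 log units; beyond the scatter) and so the six-membered aromatic ring is not required for inhibition at this level. Among these compounds, a sulfonamide on the shared core is therefore not tied to the weak end of this small set, as the single value for compound 3 might have suggested. Methanesulfonamido in place of dimethylamino on the aromatic carbon gives a 1.1-fold lower number from compound 1 to compound 4 (0.04 log units; within the scatter) and thus no difference that can be told from the scatter, while nothing measured here explains either step.

With only methyl and 4-methylphenyl on the sulfonyl sulfur, the compounds shown do not tell whether ethyl, a longer chain or an unsubstituted phenyl would fall nearer compound 4 or compound 3. They also leave open what an amine or a carboxylic acid at the end of such a chain would do to inhibition in this assay on this core.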